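A few compounds are considered here, and "the series" means these few. Any claim that something is new, unique, unknown or untested is made for them only; others in the source may bear on it.

- compound 1 `COc1cc(C(=O)/C=C\Nc2ccc(-c3nc4cc(OC)c(OC)c(OC)c4s3)cc2)c(Br)c(OC)c1OC`: 23200 nM
- compound 2 `COc1cc(OC)c2sc(-c3ccc(N/C=C\C(=O)c4cc(OC)c(OC)c(OC)c4Br)c(C)c3)nc2c1`: 16000 nM
- compound 3 `COc1cc(OC)c2sc(-c3ccc(N/C=C\C(=O)c4cc(OC)c(OC)c(OC)c4)c(C)c3)nc2c1`: 17000 nM

In a functional assay on MIA PaCa-2 cells (Homo sapiens) for antiproliferative activity, read by sulforhodamine B assay, with a stated time of 48 h (a higher number here means a weaker inhibitor, a lower number a stronger inhibitor), compound 2 gives 16000 nM. This value lies within the usual scatter of the values for compound 1 and compound 3, so the three form a single group with no clear order among them.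

Compound 4 `COc1cc(C(=O)/C=C\Nc2ccc(-c3nc4cc(OC)c(OC)c(OC)c4s3)cc2C)c(Br)c(OC)c1OC` departs from compound 2 by one change to the shared core: methoxy in place of hydrogen on an aromatic carbon. Here methoxy stands in place of hydrogen on an aromatic carbon, ortho to two methoxy groups.

Within the data shown here, only one measured step changes a single place: a 1.1-fold higher number from compound 2 to compound 3 (0.03 log units; within the scatter). It replaces bromo with hydrogen elsewhere in the molecule and stays within the scatter. No measured step adds a methoxy to the core, so the data offer no direct guide to this change and no reason to favour either direction. Among the measured compounds shown here, with that single small step as the only evidence, no change beyond the scatter is expected in this assay.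

The expected step is a 1.1-fold higher number from compound 2 to compound 4 (0.05 log units; within the scatter), which would leave the new compound within the same group. For compound 4 the estimated value is 18000 nM, with an expected range from 8000 nM to 40000 nM.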

Compound 4, half-maximal inhibitory concentration: 24300 nM
Compound 4: the middle estimate sits 1.4-fold (0.13 log units) below what was measured, within the range that was stated.
By their numbers in this assay, from the lowest: compounds 2, 3, 1 and 4 (each within the scatter of the next).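

In this assay, among these compounds, methoxy in place of hydrogen on an aromatic carbon, ortho to two methoxy groups, gives a 1.5-fold higher number from compound 2 to compound 4 (0.18 log units; within the scatter), the first measured step at this position of the shared core, and it shows that this addition stays within the scatter when the bromo and the methyl are both present. A second single change now becomes readable: with that methoxy present, swapping an aromatic hydrogen for a methyl gives a 1.0-fold higher number from compound 1 to compound 4 (0.02 log units; within the scatter), so this step also stays within the scatter. The data shown offer nothing that could explain these small steps.

The compounds shown carry only hydrogen or methoxy at this position, so they leave open whether a different group there, such as an amine or a carboxylic acid, would give a step beyond the scatter. They also leave open whether replacing bromo with hydrogen would remain within the scatter in a compound that keeps the added methoxy.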